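Ester-linked coumarin furoxan: methyl on the core

A few compounds are considered here, and "the series" means these few. Any claim that something is new, unique, unknown or untested is made for them only; others in the source may bear on it.

Working notes on a set of coumarin-bearing furoxan sulfones. In a functional assay on A549 cells (Homo sapiens) for antiproliferative activity, read by MTT assay, with a stated time of 48 h (a lower number here means a stronger inhibitor, a higher number a weaker inhibitor), compound 1, `O=c1ccc2ccc(OCCOc3no[n+]([O-])c3S(=O)(=O)c3ccccc3)cc2o1`, gives 260 nM. Compound 2, `Cc1cc(=O)oc2cc(SCCOc3no[n+]([O-])c3S(=O)(=O)c3ccccc3)ccc12`, gives 120 nM in this assay. Compound 3, `O=C(COc1ccc2ccc(=O)oc2c1)OCCOc1no[n+]([O-])c1S(=O)(=O)c1ccccc1`, carries an ester in the linker and stands at the edge of the numbers shown: in this assay compound 3 gives > 20000 nM, which is a limit of the assay and not a number. Among the compounds with values here, it sits at the limit of > 20000 nM in this assay, at which 1 of the 3 values shown sits, so no step to compound 1 or compound 2 can be sized from it.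

Compound 4, `Cc1cc(=O)oc2cc(OCC(=O)OCCOc3no[n+]([O-])c3S(=O)(=O)c3ccccc3)ccc12`, is to be measured in this assay. It differs from compound 3 by methyl in place of hydrogen on an aromatic carbon, on the six-membered aromatic ring with one oxygen of the fused system, opposite the ring oxygen. Within the data shown here, no measured pair isolates this change. For a single methyl on the core, no step beyond the scatter is expected in this assay, and the estimate keeps compound 4 at a step that the limit leaves unreadable from compound 3 to compound 4 from compound 3. Compound 4 is therefore expected near 25000 nM, within 5000 nM to 100000 nM, with a limit the most likely outcome.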

Compound 4, half-maximal inhibitory concentration: 6920 nM
The estimate for compound 4 lay 3.6-fold (0.56 log units) above the measured number, and the stated range covers the measured number.
By their numbers in this assay, from the lowest: compound 2; then compound 1; then compound 4. At a limit, above all of these: compound 3.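

In this assay, methyl in place of hydrogen on an aromatic carbon, opposite the ring oxygen, gives an at least 2.8-fold lower number from compound 3 to compound 4 (0.46 log units; beyond the scatter), so this single methyl moves the ester-linked pair beyond the scatter. The value of compound 3, > 20000 nM, is a limit of the assay and not a number, so the full size of this step stays open: the limit of > 20000 nM in this assay, at which 1 of the 4 values shown sits.
The earlier compounds held no pair that isolated this change, so this is the only reading of the methyl in the compounds shown, and it holds for the ester linker alone.

Going by these compounds, whether the same methyl gives a step of this kind with the linker of compound 1 remains open. Also open, on these data alone, is how an ethyl group or an amine at this place on the core would compare with methyl.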